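The source may report more compounds than this note shows. Statements on the series, on what has been measured and on what is new or still open speak of the compounds shown alone.

Measured so far:
compound 1 `CC(C)=CCC1Cc2c(OC(=O)Nc3ccc(Cl)cc3)cc(=O)n(CCCO)c2CC1(C)C` gives 49.8% in a functional assay on PANC-1 cells (Homo sapiens) for inhibition, read by MTT assay, with a stated time of 24 h, tested at 10 uM; on this read-out higher numbers stand for more inhibition at the one concentration tested (going by the name of the read-out) and lower numbers for less inhibition
compound 2 `CC(C)=CCC1Cc2c(OC(=O)Nc3cccc(C(F)(F)F)c3)cc(=O)n(CCCO)c2CC1(C)C` gives 54.3% in this assay
compound 3 `CC(C)=CCC/C(C)=C/CC1Cc2c(OC(=O)Nc3ccc(Cl)cc3)cc(=O)n(CCCO)c2CC1(C)C` gives 47.2% in this assay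

Compound 4 `CC(C)=CCC/C(C)=C/CC1Cc2c(OC(=O)Nc3cccc(C(F)(F)F)c3)cc(=O)n(CCCO)c2CC1(C)C` has not yet been measured in this assay. It differs from compound 3 by 3-(trifluoromethyl)phenyl in place of 4-chlorophenyl on an amide-type nitrogen. The same change has already been made once among these compounds, from compound 1 to compound 2, where it reads 3-(trifluoromethyl)phenyl in place of 4-chlorophenyl on an amide-type nitrogen and sits at a place described in the same words; there it gave a number 4.5 percentage points higher from compound 1 to compound 2 (within the scatter). The cores of the two pairs are not the same: compound 3 carries 3-methylbut-2-en-1-yl in place of hydrogen on a saturated chain carbon bound to a double-bonded chain carbon, which gave a number 2.6 percentage points lower from compound 1 to compound 3 (within the scatter). The expected step for compound 4 is a number 4.3 percentage points higher from compound 3 to compound 4 (within the scatter), because the same change earlier gave a number 4.5 percentage points higher from compound 1 to compound 2 (within the scatter). Compound 4 is therefore estimated at 51.5%, with a range from 42% to 61%.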

Compound 4, a percentage reported as inhibition, at one concentration (the size of the read-out at that concentration, not a potency): 44%
Compound 4: the middle estimate sits 7.5 percentage points above what was measured, and the stated range covers the measured number.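

In this assay, putting 3-(trifluoromethyl)phenyl in place of 4-chlorophenyl on the core of compound 3 gives a number 3.2 percentage points lower from compound 3 to compound 4 (within the scatter), and the two results for this change do not differ meaningfully: the same change on two cores in this assay, a number 4.5 percentage points higher (within the scatter) from compound 1 to compound 2 and a number 3.2 percentage points lower (within the scatter) from compound 3 to compound 4, 7.7 percentage points apart, within the scatter of two such steps

Adding 3-methylbut-2-en-1-yl gives a number 10.3 percentage points lower from compound 2 to compound 4 (beyond the scatter), a modest step, yet it too cannot be separated from its earlier counterpart: the same change on two cores in this assay, a number 2.6 percentage points lower (within the scatter) from compound 1 to compound 3 and a number 10.3 percentage points lower (beyond the scatter) from compound 2 to compound 4, 7.7 percentage points apart, within the scatter of two such steps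

So neither change is shown to depend on the core, but two pairs with such small differences do not prove that either change carries over reliably, nor do they fix a direction for the aryl swap.

The compounds shown leave open how an amine or a carboxylic acid on the phenyl ring, in place of chlorine or trifluoromethyl, would read in this assay.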